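The source may report more compounds than this note shows. Statements on the series, on what has been measured and on what is new or still open speak of the compounds shown alone.

Measured compounds:
compound 1, `O=C(O)CN1C(=O)/C(=C/c2nc3ccccc3n2Cc2ccc(Br)cc2)SC1=S` — 8720 nM
compound 2, `O=C(O)CN1C(=O)/C(=C/c2nc3ccccc3n2Cc2ccc([N+](=O)[O-])cc2)SC1=S` — 7760 nM

In a functional assay on MDA-MB-231 cells (Homo sapiens) for cytotoxicity, read by MTT assay, with a stated time of 48 h (on this read-out higher numbers stand for weaker inhibition and lower numbers for stronger inhibition), compound 1 gives 8720 nM and compound 2 gives 7760 nM. Among the measured compounds shown here, on these two numbers compound 2 stands lowest, with compound 1 nearest, but the only measured step, a 1.1-fold lower number from compound 1 to compound 2 (0.05 log units; within the scatter), lies within the scatter, so the two compounds cannot be told apart on this read-out.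

Compound 3, `CCn1c(/C=C2\SC(=S)N(CC(=O)O)C2=O)nc2ccccc21`, is yet to be measured in this assay. It differs from compound 2 by methyl in place of 4-nitrophenyl on a saturated chain carbon bound to an aromatic nitrogen. For the measured compounds named here, the one measured step exchanges a substituent on that 4-nitrophenyl ring; it does not remove the ring itself, so it bears on the present change only loosely, and it showed no shift beyond the scatter. Nothing measured here speaks to taking the whole ring away. The account therefore expects no shift beyond the scatter, with a slight lean toward a higher number, a 1.5-fold higher number from compound 2 to compound 3 (0.19 log units; within the scatter), and estimates for compound 3 a value of 12000 nM, within a range from 5000 nM to 30000 nM.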

Compound 3, half-maximal inhibitory concentration: 1880 nM
Compound 3: middle estimate off by 6.4-fold (0.81 log units), on the high side; the measured number lies below the stated range.
By their numbers in this assay, from the lowest: compound 3; then compounds 2 and 1 (each within the scatter of the next).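

The earlier pair showed only that exchanging bromo for nitro on the ring left the number in this assay within the scatter, which said nothing about the ring itself. Compound 3 shows that this position does respond to a larger change: going from 4-nitrobenzyl to ethyl gives a 4.1-fold lower number from compound 2 to compound 3 (0.62 log units; beyond the scatter), and going from the bromo counterpart to the same ethyl gives a 4.6-fold lower number from compound 1 to compound 3 (0.67 log units; beyond the scatter), so among these three compounds the lower number goes with methyl in place of either substituted phenyl on the saturated chain carbon bound to the aromatic nitrogen, and neither ring-bearing compound goes against this. Nothing available explains why the number falls with this change.

With only these three compounds, the loss of the ring cannot be separated from the shortening of the whole substituent, and an unsubstituted benzyl, a propyl or a longer chain would be needed to tell where along that series the number moves. From the compounds shown here alone, it also stays open whether a smaller group such as a plain methyl directly on the aromatic nitrogen, or a chain ending in an amine, would lower the number further or raise it again.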